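The compounds below may be only part of what the source reports. "The series", "measured", "known", "first", "only" and "open" are said of these compounds alone.

Compound 1 `COc1ccc(F)cc1CNCCCNc1ccnc2cc(Cc3ccccc3)ccc12` gives 9.47 in a physicochemical assay for acid dissociation. Compound 2 `COc1ccc(F)cc1CNCCCNc1ccnc2cc(Cc3ccc(F)cc3)ccc12` gives 9.47 in this assay, and compound 3 `COc1ccc(F)cc1CNCCCNc1ccnc2cc(CC(C)C)ccc12` gives 9.47 in this assay, level with compounds 1 and 2. Every step among these three stays within the scatter: no change at the digits printed from compound 1 to compound 2 (within the scatter), no change at the digits printed from compound 1 to compound 3 (within the scatter) and no change at the digits printed from compound 2 to compound 3 (within the scatter). Compound 4 `COc1ccc(F)cc1CNCCCNc1ccnc2cc(-c3cccc4ccccc34)ccc12` differs from compound 3 in one place: naphthalen-1-yl in place of isobutyl on an aromatic carbon. For the measured compounds named here, the steps that bear on this are those from compound 1 and from compound 2 to compound 3, which exchanged groups at the same place on the shared core without moving this assay, so this further exchange is expected to leave this assay unchanged beyond the scatter, a step of no change at the digits printed from compound 3 to compound 4 (within the scatter). Compound 4 is therefore estimated at 9.47, between 9.2 and 9.75.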

Compound 4, acid dissociation constant: 9.47
The estimate for compound 4 equals the measured number at the digits printed; measured number inside the range.
By their numbers in this assay, from the lowest: compounds 1, 2, 3 and 4 (each within the scatter of the next).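

The exchange at this aromatic carbon, unlike the earlier ones on a saturated chain carbon, replaces the whole substituent, and this assay shows no change at the digits printed from compound 3 to compound 4 (within the scatter), no change at the digits printed from compound 2 to compound 4 (within the scatter) and no change at the digits printed from compound 1 to compound 4 (within the scatter). Among these four compounds, then, the reading holds even when naphthalen-1-yl, with its 2 six-membered aromatic rings of carbon only, enters in place of isobutyl, 4-fluorobenzyl or benzyl. No supporting evidence bears on this result. Going by these compounds, whether an amine or a carboxylic acid at this position would leave the reading level remains open.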